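Moving the Dimethylamino Group Out onto a Methylene Linker

The source may report more compounds than this note shows. Statements on the series, on what has been measured and on what is new or still open speak of the compounds shown alone.

Compound 1 `Cc1nc(-c2ccc(F)cc2)ccc1C(=O)Nc1ccc2scnc2c1` gives 7.5 in an in vitro functional assay on 1321-N1 cells for antagonist activity at transient receptor potential cation channel subfamily V member 1 (Homo sapiens), read by FLIPR and calcium flux (on this read-out higher numbers stand for higher potency (the scale is a negative logarithm) and lower numbers for lower potency), and compound 3 `O=C(Nc1ccc2cccnc2c1)c1ccc(-c2ccc(F)cc2)nc1` gives 8.2 in this assay. Compound 2 `Cc1nc(-c2ccc(F)cc2)ccc1C(=O)Nc1ccc2sc(N(C)C)nc2c1` reaches only a limit of the assay, < 5.8 in this assay. Compound 2 thus sits at the limit of < 5.8 in this assay, at which 1 of the 3 values shown sits. Among the compounds with values here, the one measured step reaching it is a number at least 1.70 log units lower from compound 1 to compound 2 (beyond the scatter). Compound 4 `Cc1nc(-c2ccc(F)cc2)ccc1C(=O)Nc1ccc2sc(CN(C)C)nc2c1` differs from compound 2 by (dimethylamino)methyl in place of dimethylamino on an aromatic carbon. Within the data shown here, no measured step changes this group directly; only the step to compound 2 bears on the position, and compound 4 keeps a substituent there, so only a small recovery toward a measurable number is expected, with the estimated step of a number at least 0.20 log units higher from compound 2 to compound 4 (that floor lies within the scatter). Compound 4 is therefore expected at 6, between 5.4 and 6.9, in this assay.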

Compound 4, negative logarithm of the antagonist equilibrium constant: < 6.7
Compound 4 gave a limit, no number; the forecaster's own chance of this, stated with the estimate: 40%; the middle value does not contradict the limit.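

In this assay compound 4 also ends in a limit, not a number: the limit of < 6.7 in this assay, at which 1 of the 4 values shown sits. Even so, putting (dimethylamino)methyl in place of hydrogen on this aromatic carbon gives a number at least 0.80 log units lower from compound 1 to compound 4 (beyond the scatter), so a real loss remains with the methylene linker in place. Going by these compounds, the step between compound 2 and compound 4 cannot be read, and whether the linker recovers any potency stays unknown.

Still open, on these data alone, is how far the true value of compound 4 lies from its limit. Also open, as far as these compounds go, is whether a methyl group or a primary amine at this position would keep the potency of compound 1.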